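Methyl for Hydrogen on a Ring Oxygen: Tolerance Compared

A few compounds are considered here, and "the series" means these few. Any claim that something is new, unique, unknown or untested is made for them only; others in the source may bear on it.

Measured in an ADME assay on HepG2 2.2.15 cells (Homo sapiens) for cytotoxicity, read by MTT assay, with stated times of 48 h and 9 days; a higher number here means that more compound is tolerated, a lower number that less compound is tolerated:
compound 1 `COc1ccc(CNC(=O)/C=C/c2coc3cc(O)ccc3c2=O)cc1`: 718000 nM
compound 2 `COc1ccc(CNC(=O)/C=C/c2coc3cc(OC)ccc3c2=O)cc1`: 43000 nM
compound 3 `Cc1ccccc1NC(=O)/C=C/c1coc2cc(O)ccc2c1=O`: 374000 nM

Compound 2 differs from compound 1 by methyl in place of hydrogen on an oxygen on an aromatic ring, and that single change made a 17-fold lower number from compound 1 to compound 2 (1.22 log units; beyond the scatter). Compound 3 carries a different core from compound 1; the difference between the two cores is not broken down here. The values of compound 3 and compound 1 lie within the usual scatter of each other, so no order between them is drawn, whereas compound 2 gives a clearly lower number than compound 3.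

Compound 4 `COc1ccc2c(=O)c(/C=C/C(=O)Nc3ccccc3C)coc2c1` has not been measured. It differs from compound 3 by methyl in place of hydrogen on an oxygen on an aromatic ring, the same change at the same place as that from compound 1 to compound 2. Because a 17-fold lower number from compound 1 to compound 2 (1.22 log units; beyond the scatter), the corresponding step from compound 3 to compound 4 is expected to be a 15-fold lower number from compound 3 to compound 4 (1.17 log units; beyond the scatter) in this assay. This expectation rests on one pair only, compound 1 and compound 2, on another core. Compound 4 is therefore estimated to give 25000 nM in this assay, with a likely span from 8000 nM to 90000 nM.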

Compound 4, half-maximal cytotoxic concentration: 59700 nM
Beside the measured number, compound 4's estimate is 2.4-fold (0.38 log units) below it; low and high end bracket the measured number.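

In this assay, methyl in place of hydrogen on the ring oxygen also lowers the number on the second core, with a 6.3-fold lower number from compound 3 to compound 4 (0.80 log units; beyond the scatter), so the direction of the change carries from the one core to the other, but its size does not: the same change on two cores in this assay, a 17-fold lower number (1.22 log units; beyond the scatter) from compound 1 to compound 2 and a 6.3-fold lower number (0.80 log units; beyond the scatter) from compound 3 to compound 4, 2.7-fold (0.43 log units) apart, beyond the scatter of two such steps With the methoxy group present on both, 2-methylphenyl in place of 4-methoxybenzyl on the amide-type nitrogen gives a 1.4-fold higher number from compound 2 to compound 4 (0.14 log units; within the scatter), so no order is drawn between these two compounds. Two pairs show neither why the two steps differ in size nor how large the step would be on any further core.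

The compounds shown leave open whether a longer chain on the ring oxygen, such as ethyl, or an amine in place of the hydroxy group would also lower the number. They also leave open how the step would behave with a carboxylic acid on the group carried by the amide-type nitrogen.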